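The source may report more compounds than this note shows. Statements on the series, on what has been measured and on what is new or still open speak of the compounds shown alone.

Compound 2 `CC1=C(C(=O)SC(C)C)C(c2ccsc2)NC(=O)N1` gives 24% in an assay on membranes from CHO cells for displacement of a labelled ligand from adenosine receptor A1 (Homo sapiens), read by scintillation counting, with a stated time of 60 min, tested at 1 uM; on this read-out higher numbers stand for more inhibition at the one concentration tested (going by the name of the read-out) and lower numbers for less inhibition. Among the measured compounds shown here, only one other compound has been measured so far: compound 1 `CC1=C(C(=O)OC(C)(C)C)C(c2ccsc2)NC(=O)N1` gives 15%, and the step of a number 9 percentage points higher from compound 1 to compound 2 (within the scatter) lies within the scatter, so the two numbers cannot be told apart. Compound 3 `CCC(C)OC(=O)C1=C(C)NC(=O)NC1c1ccsc1` differs from compound 2 in one place: sec-butoxy in place of isopropylsulfanyl on a carbonyl carbon. For the measured compounds named here, the single measured step bears on this change, since it also exchanged the group on the carbonyl carbon, and it was small. A step of about a number 6 percentage points lower from compound 2 to compound 3 (within the scatter) is therefore expected, not beyond the scatter. Compound 3 is estimated at 18%, within 5% to 35%.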

Compound 3, a percentage reported as inhibition, at one concentration (the size of the read-out at that concentration, not a potency): 5%
Compound 3: middle estimate off by 13 percentage points, on the high side; measured number inside the range.
By their numbers in this assay, from the lowest: compounds 3, 1 and 2 (each within the scatter of the next, the first and the last beyond it).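

In this assay the change from isopropylsulfanyl to sec-butoxy on the carbonyl carbon brings a number 19 percentage points lower from compound 2 to compound 3 (beyond the scatter) and so shows that this position can respond to what it carries. The two esters read differently: a number 10 percentage points lower from compound 1 to compound 3 (within the scatter) means that sec-butyl and tert-butyl on that oxygen cannot be told apart. No measurement shown gives a reason for the larger step. Sulfur and oxygen change together with the carbon chain in that step, so their separate shares stay open. From the compounds shown here alone, how an amine-linked isopropyl group or a longer chain on the oxygen would read also stays open.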